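Toward a Smaller Amide in a Well-Tolerated Series

The source may report more compounds than this note shows. Statements on the series, on what has been measured and on what is new or still open speak of the compounds shown alone.

Compound 1 `COc1ccc(-c2cnc(NC(=O)c3ccccc3OC)n2C)cc1`: > 100000 nM
Compound 2 `COc1ccc(-c2cnc(NC(=O)c3ccc(O)cc3)n2C)cc1`: > 100000 nM
Compound 3 `COc1ccc(-c2cnc(NC(C)=O)n2C)cc1`: not yet measured

In a toxicity assay on THP-1 cells (Homo sapiens) for inhibition (a lower number here means that less compound is tolerated, a higher number that more compound is tolerated), compound 1 shows only a limit of the assay, > 100000 nM. Compound 2 likewise shows only a limit, > 100000 nM. Within the data shown here, the one measured step, a step that the two limits leave unreadable from compound 1 to compound 2, therefore carries no readable size. Compound 2 thus stands at the limit, the same position recorded for both measured values in the limit of > 100000 nM in this assay, at which 2 of the 2 values shown sit. Compound 3 differs from compound 2 in one place: methyl in place of 4-hydroxyphenyl on a carbonyl carbon. Among the measured compounds shown here, no measured step gives a size to carry over, and no step beyond the scatter is expected. Compound 3 is estimated at 150000 nM, between 60000 nM and 400000 nM. The expected step is a step that the limit leaves unreadable from compound 2 to compound 3.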

Compound 3, half-maximal cytotoxic concentration: > 100000 nM
Compound 3: a limit, no number (the forecaster's own chance of this, stated with the estimate: 75%); the middle value lies beyond the limit too.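

No step among compound 1, compound 2 and compound 3 can be read in this assay: the limit of > 100000 nM in this assay, at which 3 of the 3 values shown sit.

The compounds shown leave open at what concentration any of the three reaches half-maximal cytotoxicity, and whether the group on the carbonyl carbon alters it.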